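Adding a chloro group to compound 2

A few compounds are considered here, and "the series" means these few. Any claim that something is new, unique, unknown or untested is made for them only; others in the source may bear on it.

Going by the values given here, in a functional assay on A549 cells (Homo sapiens) for antiproliferative activity, read by MTT assay, with a stated time of 48 h (on this read-out higher numbers stand for weaker inhibition and lower numbers for stronger inhibition), compound 2 (`COc1ccc(-c2nn(-c3ccccc3)cc2-c2nc3cc(Cl)ccc3[nH]2)cc1`) gives 3130 nM, the lower of the two numbers so far, while compound 1 (`Fc1ccc(-c2nn(-c3ccccc3)cc2-c2nc3cc(Cl)c(Cl)cc3[nH]2)cc1`) gives 15700 nM. Compound 3 (`COc1ccc(-c2nn(-c3ccccc3)cc2-c2nc3cc(Cl)c(Cl)cc3[nH]2)cc1`) differs from compound 2 by one change: chloro in place of hydrogen on an aromatic carbon. Compound 1 shares that chloro pattern and gives 15700 nM, although it also differs elsewhere, which points towards weaker inhibition. In this assay a modest step is expected, an estimated 1.9-fold higher number from compound 2 to compound 3 (0.28 log units; within the scatter), towards a higher number and near the edge of the scatter. For compound 3 the estimate is 6000 nM, with an expected range of 2200 nM to 16000 nM.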

Compound 3, half-maximal inhibitory concentration: 7330 nM
For compound 3 the middle estimate is 1.2-fold (0.09 log units) below the measured one, and the stated range covers the measured number.
By their numbers in this assay, from the lowest: compound 2; then compound 3; then compound 1.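

In this assay there is a 2.3-fold higher number from compound 2 to compound 3 (0.37 log units; beyond the scatter) when chloro replaces hydrogen on this aromatic carbon, ortho to a chloro group, so the added chloro weakens inhibition here. With the same chloro pattern on both compounds, there is a 2.1-fold lower number from compound 1 to compound 3 (0.33 log units; beyond the scatter) for methoxy in place of fluoro on an aromatic carbon, so that change strengthens inhibition. Nothing available bears on the reason for either step.

Going by these compounds, whether a methyl group or an amine on this aromatic carbon would act as chloro does remains open. So does whether methoxy in place of fluoro gives a similar step with only one chloro group present.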